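Series notes: amine exchange on the shared core

The source may hold more compounds than are shown below. What is called first, only, known or untested is meant among the compounds shown, and "the series" means these compounds.

Two members of the series have been run in a functional assay on the whole organism (strain Wister albino) for inhibition, with Rattus norvegicus as the target, read by paw edema, with stated times of 1 h and 4 h, at a dose of 50 mg/kg by the intraperitoneal route; a lower number here means less inhibition, a higher number more inhibition at the dose given (going by the name of the read-out). Compound 1 `CCOC(=O)c1c(-c2ccc(Cl)c(Cl)c2)cc(-c2ccccc2)nc1Nc1ccc(Cl)cc1` gives 62.4%. Among the compounds with values here, compound 2 `CCOC(=O)c1c(-c2ccc(C)cc2)cc(-c2ccccc2)nc1N1CCCCC1` gives 78%, the higher of the two numbers, with compound 1 below it by more than the usual scatter; these two differ in more than one place, so no single step connects them. Compound 3 `CCOC(=O)c1c(-c2ccc(C)cc2)cc(-c2ccccc2)nc1Nc1ccc(Cl)cc1` differs from compound 2 in one place: (4-chlorophenyl)amino in place of piperidin-1-yl on an aromatic carbon. Because the same (4-chlorophenyl)amino is carried by compound 1 at 62.4%, a modest fall from compound 2 is expected, possibly within the scatter. Compound 3 is expected to give 68%, within 55% to 80%. The expected step is a number 10 percentage points lower from compound 2 to compound 3 (within the scatter).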

Compound 3, a percentage reported as inhibition, in the whole organism at one dose (the size of the read-out at that dose, not a potency): 79.4%
Compound 3: middle estimate off by 11.4 percentage points, on the low side; measured number inside the range.
By their numbers in this assay, from the lowest: compound 1; then compounds 2 and 3 (each within the scatter of the next).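

Series notes, continued: on the aromatic carbon next to the ring nitrogen, (4-chlorophenyl)amino in place of piperidin-1-yl gives a number 1.4 percentage points higher from compound 2 to compound 3 (within the scatter) in this assay and so does not separate the two amines at this dose. With (4-chlorophenyl)amino held fixed, 4-methylphenyl in place of 3,4-dichlorophenyl gives a number 17 percentage points higher from compound 1 to compound 3 (beyond the scatter) and so the aryl group does separate the compounds. No measurement at hand explains either step. Open, as far as these compounds go, is whether morpholin-4-yl or unsubstituted phenylamino at this position would read the same. Also open, from the compounds shown here alone, is whether the two amines remain level alongside 3,4-dichlorophenyl.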